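Series notes: the next step from compound 2

The compounds below may be only part of what the source reports. "The series", "measured", "known", "first", "only" and "open" are said of these compounds alone.

Measured so far in a functional assay on cells (Cancer cell lines, Homo sapiens) for cytotoxicity, read by sulforhodamine B assay, with a stated time of 48 h; on this read-out higher numbers stand for weaker inhibition of growth and lower numbers for stronger inhibition of growth:
compound 1 `O=C1N=C(N2N=C(c3ccccc3)CC2c2ccccc2O)S/C1=C1/C(=O)Nc2ccccc21`, 17800 nM
compound 2 `COc1ccc(C2CC(c3ccccc3)=NN2C2=NC(=O)/C(=C3\C(=O)Nc4ccccc43)S2)cc1`, 4270 nM
compound 3 `COc1ccc(C2CC(c3ccccc3)=NN2C2=NC(=O)/C(=C3\C(=O)Nc4ccc(Br)cc43)S2)cc1`, 360 nM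

Compound 2 stands second highest of the three numbers in this assay, with a 4.2-fold lower number from compound 1 to compound 2 (0.62 log units; beyond the scatter) and a 12-fold lower number from compound 2 to compound 3 (1.07 log units; beyond the scatter) on either side of it. Compound 4 `COc1ccc(C2CC(c3ccc4ccccc4c3)=NN2C2=NC(=O)/C(=C3\C(=O)Nc4ccccc43)S2)cc1` is the untested partner: naphthalen-2-yl in place of phenyl on a carbon with a double bond to nitrogen. Neither measured step touches this position; the change from compound 1 to compound 2 concerns the aryl on a saturated ring carbon and the change from compound 2 to compound 3 concerns a bromo on an aromatic carbon, so nothing here shows how the group on the carbon with a double bond to nitrogen matters. The step from compound 2 to compound 4 is therefore expected to be small, a 1.4-fold lower number from compound 2 to compound 4 (0.15 log units; within the scatter), direction uncertain. Compound 4 is estimated at 3000 nM, range 1000 nM to 12000 nM.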

Compound 4, concentration for total growth inhibition: 13600 nM
Beside the measured number, compound 4's estimate is 4.5-fold (0.66 log units) below it, and the stated range ends below it.
By their numbers in this assay, from the lowest: compound 3; then compound 2; then compounds 4 and 1 (each within the scatter of the next).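

In this assay the group on the carbon with a double bond to nitrogen does matter: naphthalen-2-yl in place of phenyl gives a 3.2-fold higher number from compound 2 to compound 4 (0.50 log units; beyond the scatter), so the second aromatic ring goes with weaker inhibition of growth in this one pair. This is the only step shown at this position, and it runs opposite in direction to the two steps at the other positions. No evidence at hand accounts for it. Still open, going by these compounds, is whether methyl or 4-aminophenyl at this position would hold or lower the number, and whether the bromo step carries over to the naphthalen-2-yl compound.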